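Sulfonamide nitrogen substituents on a thiourea series

This account rests on a few compounds, and the source may have more. Where it says the series, first, only, none or still open, it means among the compounds named here.

Measured compounds:
compound 1 `NS(=O)(=O)c1ccc(N/C(S)=N\c2ccnc3cc(C(F)(F)F)ccc23)cc1` — 36600 nM
compound 2 `N=C(N)NS(=O)(=O)c1ccc(N/C(S)=N\c2ccnc3cc(C(F)(F)F)ccc23)cc1` — 23900 nM

In a functional assay on AS49-RAW cells (Homo sapiens) for antiproliferative activity, read by sulforhodamine B assay, with a stated time of 48 h (on this read-out lower numbers stand for stronger inhibition and higher numbers for weaker inhibition), compound 1 gives 36600 nM and compound 2 gives 23900 nM. Among the compounds with values here, compound 2 holds the lowest of the two numbers, but the only step measured, a 1.5-fold lower number from compound 1 to compound 2 (0.19 log units; within the scatter), stays within the scatter, so the two values are read as alike.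

Compound 3 `O=S(=O)(Nc1ccccn1)c1ccc(N/C(S)=N\c2ccnc3cc(C(F)(F)F)ccc23)cc1` has not yet been measured in this assay. It differs from compound 2 by a group of 6 heavy atoms (5 carbon, 1 nitrogen; one six-membered aromatic ring with 1 hetero atom) in place of a group of 3 heavy atoms (1 carbon, 2 nitrogen; no ring), on a sulfonamide nitrogen. Within the data shown here, the one step that bears on this position, a 1.5-fold lower number from compound 1 to compound 2 (0.19 log units; within the scatter), shows that exchanging the group on the sulfonamide nitrogen left the number essentially where it was. With nothing else to go on, no step beyond the scatter is expected in this assay in either direction.

Compound 3 is therefore estimated at 25000 nM, with a range of 8000 nM to 80000 nM, which means an expected step of a 1.0-fold higher number from compound 2 to compound 3 (0.02 log units; within the scatter).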

Compound 3, half-maximal inhibitory concentration: 33500 nM
The estimate for compound 3 lay 1.3-fold (0.13 log units) below the measured number; the range from low to high includes it.
By their numbers in this assay, from the lowest: compounds 2, 3 and 1 (each within the scatter of the next).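

In this assay, pyridin-2-yl on the sulfonamide nitrogen behaves like the open-chain group of compound 2: the comparison with the unsubstituted sulfonamide gives a 1.1-fold lower number from compound 1 to compound 3 (0.04 log units; within the scatter), and the comparison between the two substituents gives a 1.4-fold higher number from compound 2 to compound 3 (0.15 log units; within the scatter). An aromatic ring on this nitrogen therefore makes no readable difference, and hydrogen and both larger groups now stand within the scatter of one another, though only these three compounds support that reading. No measurement is available that would explain this flat result.

Still open, going by these compounds, is whether a carboxylic acid, an amine or a longer alkyl chain on the sulfonamide nitrogen would move the number beyond the scatter. Also open, on these data alone, is whether a change elsewhere in the shared core, such as a nitrile in place of trifluoromethyl, would do so.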